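The compounds below may be only part of what the source reports. "The series", "measured", "known", "first", "only" and "open" are said of these compounds alone.

In a functional assay on U-87MG ATCC cells for antiproliferative activity against U-87 MG (Homo sapiens), read by spectrophotometry, with a stated time of 2 days (a higher number here means a weaker inhibitor of growth, a lower number a stronger inhibitor of growth), two compounds that share one core have been tested so far. Compound 1 `Cc1cc(C)cc(Nc2ncc(C(F)(F)F)c(N3Cc4cccc(N(C)S(C)(=O)=O)c4C3)n2)c1` gives > 30000 nM, which is a limit of the assay and not a number. Compound 2 `CN(c1cccc2c1CN(c1nc(Nc3cccc(C(F)(F)F)c3)ncc1C(F)(F)F)C2)S(C)(=O)=O` gives > 30000 nM, which is again a limit and not a number. So compound 2 has no exact position yet, and the evidence reads: the limit of > 30000 nM in this assay, at which 2 of the 2 values shown sit.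

Compound 3 `CN(c1cccc2c1CN(c1nc(Nc3cc(Cl)cc(C(F)(F)F)c3)ncc1C(F)(F)F)C2)S(C)(=O)=O` differs from compound 2 by one change, chloro in place of hydrogen on an aromatic carbon, which turns 3-(trifluoromethyl)phenyl into 3-chloro-5-(trifluoromethyl)phenyl. Among the compounds with values here, the only measured step that bears on this is a step that the two limits leave unreadable from compound 1 to compound 2. It placed 3-(trifluoromethyl)phenyl where 3,5-dimethylphenyl stood, on the same nitrogen, and it offers no size or direction to carry over. Within the data shown here, no step of definite size or direction can therefore be expected in this assay, and the likeliest outcome is a result near the same limit. The expected change is a number no higher from compound 2 to compound 3 (the limit leaves the size open), and this is only an estimate. The estimated value for compound 3 is 30000 nM, with an expected range from 10000 nM to 60000 nM.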

Compound 3, concentration for 50% growth inhibition: 5500 nM
Estimate against measurement, compound 3: 5.5-fold (0.74 log units) above; the measured number lies below the stated range.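

In this assay, chloro in place of hydrogen on an aromatic carbon, meta to a trifluoromethyl group, gives an at least 5.4-fold lower number from compound 2 to compound 3 (0.73 log units; beyond the scatter), so this position on the ring can respond to a single added atom, which the earlier pair could not show. Within the data shown here, replacing the 3,5-dimethylphenyl on the nitrogen with 3-chloro-5-(trifluoromethyl)phenyl gives an at least 5.4-fold lower number from compound 1 to compound 3 (0.73 log units; beyond the scatter), and compound 3 is the first compound here to give a measured number instead of a limit. Both steps give only a minimum size, because neither starting compound has an exact value and each sits at a limit of the assay: the limit of > 30000 nM in this assay, at which 2 of the 3 values shown sit.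

As far as these compounds go, it remains open whether chloro itself matters or whether another group at this place, such as bromo, methoxy or nitrile, would give a similar result with the trifluoromethyl kept. A 3,5-dichlorophenyl group on the same nitrogen would help show whether the trifluoromethyl is needed alongside the chloro.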